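This account rests on a few compounds, and the source may have more. Where it says the series, first, only, none or still open, it means among the compounds named here.

Compound 1 `O=C1c2nccnc2C(=O)N1c1ccc(Cl)cc1`: 86000 nM
Compound 2 `O=C1c2cccnc2C(=O)N1c1ccc(Cl)cc1`: 92000 nM
Compound 3 `CCCCCc1ccc(N2C(=O)c3cccnc3C2=O)cc1`: 18000 nM

In an ADME assay on Vero cells (Chlorocebus sabaeus) for cytotoxicity (on this read-out higher numbers stand for weaker inhibition and lower numbers for stronger inhibition), compound 1 gives 86000 nM and compound 2 gives 92000 nM, two numbers that lie within the scatter of each other; how their cores differ is not broken down here. Compound 3 gives 18000 nM in this assay. The change from compound 2 to compound 3 is pentyl in place of chloro on an aromatic carbon and it made a step of a 5.1-fold lower number from compound 2 to compound 3 (0.71 log units; beyond the scatter).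

Compound 4 `CCCCCc1ccc(N2C(=O)c3nccnc3C2=O)cc1` has not yet been measured in this assay. It arises from compound 1 by pentyl in place of chloro on an aromatic carbon, the same change that led from compound 2 to compound 3. Among the measured compounds shown here, on the strength of that single earlier step, a 5.1-fold lower number from compound 2 to compound 3 (0.71 log units; beyond the scatter), a step of about a 5.1-fold lower number from compound 1 to compound 4 (0.70 log units; beyond the scatter) is expected here as well, resting on only one precedent. Compound 4 is therefore estimated at 17000 nM, within an expected range from 8000 nM to 40000 nM.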

Compound 4, half-maximal inhibitory concentration: 16000 nM
For compound 4 the middle estimate is 1.1-fold (0.03 log units) above the measured one, and the stated range covers the measured number.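

In this assay, pentyl in place of chloro gave a 5.4-fold lower number from compound 1 to compound 4 (0.73 log units; beyond the scatter), so the change carried over to the core of compound 1 with a step of much the same size as on the core of compound 2: the same change on two cores in this assay, a 5.1-fold lower number (0.71 log units; beyond the scatter) from compound 2 to compound 3 and a 5.4-fold lower number (0.73 log units; beyond the scatter) from compound 1 to compound 4, 1.1-fold (0.02 log units) apart, within the scatter of two such steps. For these two cores, then, the step from chloro to pentyl can be treated as transferable on this read-out. Among the compounds shown here, it rests on only two pairs, however, and shows neither that it would hold on any other core nor why the number falls.

The compounds shown leave open how the number moves with a shorter chain such as propyl or a longer one such as octyl in place of pentyl. Going by these compounds, an amine or a carboxylic acid in that place also remains open.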